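The source may hold more compounds than are shown below. What is called first, only, known or untested is meant among the compounds shown, and "the series" means these compounds.

Measured compounds:
Compound 1, `Cc1nc(C)c(C(=O)Nc2ccc(F)c(-c3nc4ncc(-c5cccnc5Cl)cn4n3)c2)o1`, in an ADME assay on microsomes from liver (Mus musculus) for metabolic stability, read by LC-MS (a lower number here means that the compound disappears faster, a higher number that the compound lasts longer), gives > 1.5 h, which is a limit of the assay and not a number.
Compound 2, `O=C(Nc1ccc(F)c(-c2nc3ncc(-c4cc(F)cc(F)c4)cc3[nH]2)c1)N1CCCC1`, in this assay gives 0.128 h.
Compound 3, `Cc1nc(C)c(C(=O)Nc2ccc(F)c(-c3nc4ncc(-c5ccccc5Cl)cn4n3)c2)o1`, in this assay gives > 1.5 h, which is again a limit rather than a number.

Within the data shown here, compound 2 therefore stands alone as the only real number among the three; the other two sit at the limit of > 1.5 h in this assay, at which 2 of the 3 values shown sit. Among the measured compounds shown here, the single one-change step among the measured compounds, a step that the two limits leave unreadable from compound 1 to compound 3, cannot be read, since both of its ends are limits, and it alters a different position on a different core in any case.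

Compound 4, `O=C(Nc1ccc(F)c(-c2nc3ncc(-c4ccc(F)cc4)cc3[nH]2)c1)N1CCCC1`, is not yet measured. It differs from compound 2 in one place: 4-fluorophenyl in place of 3,5-difluorophenyl on an aromatic carbon. For the measured compounds named here, no measured step bears on this change, so there is no ground to expect a shift beyond the usual scatter in either direction. Compound 4 is thus expected to sit close to compound 2, with an expected step of a 1.2-fold higher number from compound 2 to compound 4 (0.07 log units; within the scatter). The estimate for compound 4 is 0.15 h, with a range from 0.06 h to 0.4 h.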

Compound 4, half-life: 0.095 h
For compound 4 the middle estimate is 1.6-fold (0.20 log units) above the measured one; measured number inside the range.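

On this core, 4-fluorophenyl in place of 3,5-difluorophenyl on the aromatic carbon two atoms from the ring nitrogen gives a 1.3-fold lower number from compound 2 to compound 4 (0.13 log units; within the scatter) in this assay. Among these compounds, the earlier compounds held only one number on this core, so this is the first sign that the fluorine pattern on this phenyl ring can change without a readable shift in half-life. Nothing in the data shown bears on the cause of this result.

Going by these compounds, whether a group of another kind at this position, such as a morpholine or a carboxylic acid, would bring a readable shift stays open. Also open, on these data alone, is how this core compares with that of compound 1 and compound 3, which differ from it in more than one place and whose values are limits, so that the step between them cannot be read.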